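Adding a cinnamoyl group to the amine of compound 1

The compounds below may be only part of what the source reports. "The series", "measured", "known", "first", "only" and "open" are said of these compounds alone.

The compounds here share a core built from a threonine-like unit whose carboxyl is joined as an amide to a long saturated chain. Compound 1, `CCCCCCCCCCCCCCNC(=O)[C@@H](N)[C@@H](C)O`, gives 18700 nM in a functional assay on SW-620 cells (Homo sapiens) for cytotoxicity, read by MTT assay, with a stated time of 48 h; a higher number here means a weaker inhibitor, a lower number a stronger inhibitor. Compound 2, `CCCCCCCCCCCCCCCCCCNC(=O)[C@@H](N)[C@@H](C)O`, gives 21400 nM in this assay, and compound 3, `CCCCCCCCCCCCNC(=O)[C@@H](NC(=O)c1cccs1)[C@@H](C)O`, gives 29200 nM. Compound 1 thus has the smallest of the three numbers, though its gaps to compound 2 and to compound 3 both fall within the scatter, so no order among them can be claimed.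

Compound 4, `CCCCCCCCCCCCCCNC(=O)[C@@H](NC(=O)/C=C/c1ccccc1)[C@@H](C)O`, is not yet measured. It differs from compound 1 in one place: (2-phenylethenyl)carbonyl in place of hydrogen on an amine nitrogen. Within the data shown here, the only measured step, a 1.1-fold higher number from compound 1 to compound 2 (0.06 log units; within the scatter), concerns the length of the chain, not the amine, and so does not bear on this change. Among the measured compounds shown here, compound 3 carries a different acyl group on the same amine nitrogen alongside a shorter chain, and its value and that of compound 1 lie within the scatter of each other; no single-point step links them, so it offers only a loose hint that acylating this amine leaves the number roughly where it is.

For the measured compounds named here, with no directly relevant step, compound 4 is expected to give about 24000 nM, a step of a 1.3-fold higher number from compound 1 to compound 4 (0.11 log units; within the scatter) that need not exceed the scatter. The estimated range for compound 4 runs from 9000 nM to 65000 nM.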

Compound 4, half-maximal inhibitory concentration: 200000 nM
Estimate against measurement, compound 4: 8.3-fold (0.92 log units) below; the measured number lies above the stated range.
By their numbers in this assay, from the lowest: compounds 1, 2 and 3 (each within the scatter of the next); then compound 4.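

Among these compounds, the amine nitrogen is the first place where a single change moves the number beyond the scatter in this assay: putting (2-phenylethenyl)carbonyl in place of hydrogen there gives an 11-fold higher number from compound 1 to compound 4 (1.03 log units; beyond the scatter) and so a much weaker inhibitor. Among the compounds shown here, the only other single-place step, a change in the length of the saturated chain, gives a 1.1-fold higher number from compound 1 to compound 2 (0.06 log units; within the scatter) and stays within the scatter, so of the two places changed in these pairs, only the amine nitrogen shows a clear shift. No measurement available here accounts for the size of this step.

The compounds shown cannot tell whether the step comes from the acyl link on the amine nitrogen itself or from the rest of the (2-phenylethenyl)carbonyl group, such as its aromatic ring or its double bond outside that ring. On these data alone, a small acetyl group or a saturated 3-phenylpropanoyl group on the same amine nitrogen of compound 1 would help separate these parts, and it also remains open whether a longer chain would alter the step.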